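The source may report more compounds than this note shows. Statements on the series, on what has been measured and on what is new or still open speak of the compounds shown alone.

Measured compounds:

Compound 1, `O=C1C(=O)N(CN2CCN(c3ccnc4cc(Cl)ccc34)CC2)c2cccc(Cl)c21`: 25600 nM
Compound 2, `O=C1C(=O)N(CN2CCN(c3ccnc4cc(Cl)ccc34)CC2)c2cc(Cl)ccc21`: 67800 nM
Compound 3, `O=C1C(=O)N(CN2CCN(c3ccnc4cc(C(F)(F)F)ccc34)CC2)c2cccc(Cl)c21`: 24000 nM

All three were tested in an ADME assay on MCF-10A cells (Homo sapiens) for cytotoxicity, read by sulforhodamine B assay, with a stated time of 48 h; on this read-out higher numbers stand for weaker inhibition of growth and lower numbers for stronger inhibition of growth. Compound 1 and compound 3 share the same core and differ in one place: trifluoromethyl in place of chloro on an aromatic carbon. That change gave a 1.1-fold lower number from compound 1 to compound 3 (0.03 log units; within the scatter), so the two compounds cannot be told apart on this read-out. Compound 2 has the same atoms as compound 1, joined differently; how the two cores differ is not broken down here. In this assay compound 2 gives the highest of the three numbers, with compound 1 the nearest of the other two.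

Compound 4, `O=C1C(=O)N(CN2CCN(c3ccnc4cc(C(F)(F)F)ccc34)CC2)c2cc(Cl)ccc21`, has not yet been measured. It is to compound 2 what compound 3 is to compound 1: trifluoromethyl in place of chloro on an aromatic carbon. The place where the change is made is described in the same words for both pairs, so this is the same change, made on the core of compound 2 instead of the core of compound 1.

For the measured compounds named here, the only guide to what this change does is the pair of compound 1 and compound 3. Because that step was a 1.1-fold lower number from compound 1 to compound 3 (0.03 log units; within the scatter), the step from compound 2 to compound 4 is expected to be of a similar size, namely a 1.1-fold lower number from compound 2 to compound 4 (0.03 log units; within the scatter). On that basis, compound 4 is estimated to give 64000 nM in this assay, with a likely range from 30000 nM to 135000 nM.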

Compound 4, concentration for 50% growth inhibition: 32800 nM
Compound 4: middle estimate off by 2.0-fold (0.29 log units), on the high side; low and high end bracket the measured number.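

In this assay, putting trifluoromethyl in place of chloro on the core of compound 2 gave a modest step, a 2.1-fold lower number from compound 2 to compound 4 (0.32 log units; beyond the scatter), so the change goes with somewhat stronger inhibition of growth on this core. Set beside the earlier step on the core of compound 1, this step cannot be told apart from it, so the effect of the change carries over between these two cores as far as this read-out can show: the same change on two cores in this assay, a 1.1-fold lower number (0.03 log units; within the scatter) from compound 1 to compound 3 and a 2.1-fold lower number (0.32 log units; beyond the scatter) from compound 2 to compound 4, 1.9-fold (0.29 log units) apart, within the scatter of two such steps. For the compounds shown here, this does not show that the change has a fixed size across the series, since it rests on only two pairs of compounds, one step within the scatter and the other beyond it, and the numbers say nothing about why either step has the size it has.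

The compounds shown leave open what other groups would do on the same aromatic carbon, such as a nitrile, a methoxy group, an amine or a carboxylic acid in place of chloro or trifluoromethyl. They also leave open whether the swap of chloro for trifluoromethyl would give a step of similar size on a third core.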